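Swapping a Methyltriazole for a Phenyltetrazole on Sulfur

The source may report more compounds than this note shows. Statements on the series, on what has been measured and on what is new or still open speak of the compounds shown alone.

Measured so far:
compound 1 `Cc1nnc(SCC(=O)N/N=c2/scc(-c3ccccc3)n2-c2ccccc2)s1`: 72.4%
compound 2 `O=C(CSc1nnnn1-c1ccccc1)N/N=c1/scc(-c2ccc(F)cc2)n1-c1ccccc1`: 74.9%
compound 3 `Cn1cnnc1SCC(=O)N/N=c1/scc(-c2ccccc2)n1-c1ccccc1`: 90%

In a functional assay on C6 cells (Rattus norvegicus) for cytotoxicity, read by MTT assay, with a stated time of 24 h, tested at 6 ug/mL (a lower number here means a stronger effect, a higher number a weaker effect of the compound at the concentration tested), compound 3 stands highest, meaning weakest, of the three numbers; compound 2 lies below it beyond the scatter, and compound 1 lies lowest. For the measured compounds named here, the only measured step, a number 17.6 percentage points higher from compound 1 to compound 3 (beyond the scatter), swapped a different ring on the same sulfur. Compound 4 `O=C(CSc1nnnn1-c1ccccc1)N/N=c1/scc(-c2ccccc2)n1-c1ccccc1` differs from compound 3 by 1-phenyl-1H-tetrazol-5-yl in place of 4-methyl-4H-1,2,4-triazol-3-yl on a sulfur. Going by the values given here, no measured step covers this exact change, but compound 2 carries the same entering group, on a core differing elsewhere, and gives 74.9%. The expected step is therefore a number 14 percentage points lower from compound 3 to compound 4 (beyond the scatter). Compound 4 is estimated at 76%, within 63% to 89%.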

Compound 4, a percentage reported as activity, at one concentration (the size of the read-out at that concentration, not a potency): 52.1%
Compound 4: the middle estimate sits 23.9 percentage points above what was measured; measured number below the stated range.
By their numbers in this assay, from the lowest: compound 4; then compounds 1 and 2 (each within the scatter of the next); then compound 3.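

In this assay, for the compounds shown here, the ring on the sulfur proves able to shift the number widely: 1-phenyl-1H-tetrazol-5-yl in place of 4-methyl-4H-1,2,4-triazol-3-yl gives the largest step so far (a number 37.9 percentage points lower from compound 3 to compound 4 (beyond the scatter)), and replacing 5-methyl-1,3,4-thiadiazol-2-yl also lowers it (a number 20.3 percentage points lower from compound 1 to compound 4 (beyond the scatter)). With that phenyltetrazole held fixed, hydrogen in place of fluoro on an aromatic carbon matters too (a number 22.8 percentage points lower from compound 2 to compound 4 (beyond the scatter)), so the number depends on more than the sulfur substituent. Nothing here explains these steps. Still open, going by these compounds, is how an amine or a carboxylic acid on the sulfur chain would read, and whether fluoro has the same effect alongside the methyltriazole.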